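The source may report more compounds than this note shows. Statements on the series, on what has been measured and on what is new or still open speak of the compounds shown alone.

Three compounds share one core and differ only in a single group on it. Compound 1 `O=C(Nc1ccc(Oc2cc(C(F)(F)F)cc(C(F)(F)F)c2)cc1)c1cc(I)ccc1F` has no result in an assay on HEK293 cells for inhibition of Toll-like receptor 8 (Homo sapiens), with a stated time of 16 h (on this read-out higher numbers stand for weaker inhibition and lower numbers for stronger inhibition), and stands at "not determined" (no result reported). For compound 2 `O=C(Nc1ccc(Oc2cc(C(F)(F)F)cc(C(F)(F)F)c2)cc1)c1ccc(I)cc1F` this assay reports only a limit, > 50000 nM. For compound 3 `O=C(Nc1ccc(Oc2cc(C(F)(F)F)cc(C(F)(F)F)c2)cc1)c1ccc(O)cc1F` this assay again reports only a limit, > 50000 nM. The step that the two limits leave unreadable from compound 2 to compound 3 therefore cannot be read in size, since both of its values sit at the limit of > 50000 nM in this assay, at which 2 of the 3 values shown sit. Compound 3 thus stands at the limit of this assay, and no single number is known for any compound here.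

Compound 4 `Nc1ccc(C(=O)Nc2ccc(Oc3cc(C(F)(F)F)cc(C(F)(F)F)c3)cc2)c(F)c1` differs from compound 3 by amino in place of hydroxy on an aromatic carbon. Going by the values given here, only one measured step touches this position, and its size is unreadable, so no size can be carried over from it. The expectation is that compound 4 also stays weak, with the step that the limit leaves unreadable from compound 3 to compound 4 expected to be small. Compound 4 is estimated at 60000 nM, within 15000 nM to 300000 nM, with a strong chance that this assay again reports only a limit.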

Compound 4, half-maximal inhibitory concentration: > 50000 nM
Compound 4: only a limit was reported; the forecaster's own chance of this, stated with the estimate: 80%; the middle value does not contradict the limit.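

Compound 4 gives only a limit, as do compound 2 and compound 3, so no step among these three can be read in size: the limit of > 50000 nM in this assay, at which 3 of the 4 values shown sit.

Still open, from the compounds shown here alone, is whether any group at this position on the shared core gives a measurable value in this assay.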